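Third aryl exchange on the double-bonded chain carbon

The source may hold more compounds than are shown below. What is called first, only, known or untested is meant among the compounds shown, and "the series" means these compounds.

Measured compounds:
Compound 1 `O=C(CN1CCN(c2cc3c(cc2F)c(=O)c(C(=O)O)cn3C2CC2)CC1)Nc1ccc(C(=O)/C=C/c2ccccc2Cl)cc1` — in an assay on isolated protein for inhibition of DNA topoisomerase 1 (Homo sapiens), with a stated time of 30 min, tested at 100 uM (a lower number here means a weaker effect, a higher number a stronger effect of the compound at the concentration tested), compound 1 gives 70.8%.
Compound 2 `COc1cc(/C=C/C(=O)c2ccc(NC(=O)CN3CCN(c4cc5c(cc4F)c(=O)c(C(=O)O)cn5C4CC4)CC3)cc2)cc(OC)c1OC` — in this assay compound 2 gives 67.4%.

Compound 2 holds the lower of the two numbers, but its nearest neighbour is compound 1, and the step of a number 3.4 percentage points lower from compound 1 to compound 2 (within the scatter) lies within the scatter, so no order between the two compounds can be read from these values. Compound 3 `O=C(CN1CCN(c2cc3c(cc2F)c(=O)c(C(=O)O)cn3C2CC2)CC1)Nc1ccc(C(=O)/C=C/c2cccc([N+](=O)[O-])c2)cc1` has not yet been measured in this assay. It differs from compound 2 at a single site: 3-nitrophenyl in place of 3,4,5-trimethoxyphenyl on a double-bonded chain carbon bound to a double-bonded chain carbon. For the measured compounds named here, only one measured step bears on this change, the exchange of the group sitting on the double-bonded chain carbon bound to a double-bonded chain carbon, which gave a number 3.4 percentage points lower from compound 1 to compound 2 (within the scatter) and stayed within the scatter. Because that comparable exchange left the read-out essentially unchanged in a number 3.4 percentage points lower from compound 1 to compound 2 (within the scatter), a similar outcome is expected here. For compound 3 the expected step is a number 0.6 percentage points higher from compound 2 to compound 3 (within the scatter), which is anticipated to remain inside the scatter. The estimate for compound 3 in this assay is therefore 68%, with a range from 55% to 81%.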

Compound 3, a percentage reported as inhibition, at one concentration (the size of the read-out at that concentration, not a potency): 90.5%
For compound 3 the middle estimate is 22.5 percentage points below the measured one, outside the stated range (above it).
By their numbers in this assay, from the lowest: compounds 2 and 1 (each within the scatter of the next); then compound 3.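

Until now, exchanging the group on a double-bonded chain carbon bound to a double-bonded chain carbon had produced no readable difference in this assay, so the position could have seemed indifferent to the group it carries; 3-nitrophenyl shows otherwise, with a number 23.1 percentage points higher from compound 2 to compound 3 (beyond the scatter) and a number 19.7 percentage points higher from compound 1 to compound 3 (beyond the scatter). Compound 3 therefore stands apart from both earlier compounds, with each step beyond the scatter, whereas the compounds carrying 2-chlorophenyl and 3,4,5-trimethoxyphenyl remain within the scatter of each other. Nothing available here accounts for the separate standing of the 3-nitrophenyl group.

The compounds shown leave open whether the step belongs to the nitro group itself or to the phenyl ring as substituted here, a question that a nitrile or an amine in place of the nitro group on the same ring would address. They also leave open whether the stronger effect of compound 3 at the single tested concentration in this assay would also be seen at other concentrations.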